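The compounds below may be only part of what the source reports. "The series", "measured", "known", "first", "only" and "open" are said of these compounds alone.

Working notes on the series. Compound 1 `O[C@H]1CCCc2nc(C#Cc3ccccc3)ccc21` is one of two measured members; in a functional assay on cells (strain Sprague-Dawley) for positive allosteric modulation of metabotropic glutamate receptor 5 (Rattus norvegicus), read by FLIPR and calcium flux (a higher number here means that more compound is needed for the effect, a lower number that less compound is needed), compound 1 gives 250 nM. The other measured member is compound 2 `O=C1CCCc2nc(C#Cc3ccccc3)ccc21`, and in this assay compound 2 gives 34 nM. Compound 1 therefore stands at the higher of the two numbers, and its gap to compound 2 lies beyond the usual scatter. For the measured compounds named here, compound 3 `O[C@@H]1CCCc2nc(C#Cc3ccccc3)ccc21` remains to be measured. the two compounds have the same atoms and bonds and differ only in configuration as drawn: 1 of 1 stereo elements differ; a stereocentre at a saturated ring carbon is drawn S in compound 1 and R in compound 3 No measured pair in this set differs in configuration alone, so nothing on record sets the size or the direction of such a change. The step is estimated at a 1.7-fold lower number from compound 1 to compound 3 (0.22 log units; within the scatter), leaning slightly toward a lower number, but with a spread wide enough that either direction remains possible. Compound 3 is expected to give 150 nM in this assay, within a range of 30 nM to 800 nM.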

Compound 3, half-maximal effective concentration: 180 nM
The estimate for compound 3 lay 1.2-fold (0.08 log units) below the measured number, within the range that was stated.
By their numbers in this assay, from the lowest: compound 2; then compounds 3 and 1 (each within the scatter of the next).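

For the compounds shown here, compounds 1 and 3 form the first pair that isolates configuration at this saturated ring carbon: the fact that compounds 1 and 3 differ only in the configuration as drawn. In this assay the step for this pair is a 1.4-fold lower number from compound 1 to compound 3 (0.14 log units; within the scatter), so the drawn configuration at this carbon, S or R, does not separate the two compounds. With a hydroxyl group at this position, the data therefore give no sign that either configuration is favoured.

On these data alone, it remains open whether this holds for other groups on the same carbon, such as an amine or a methoxy group, where a matched S and R pair would allow the same comparison. As far as these compounds go, it also remains open whether any such pair would give a step beyond the scatter.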